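The compounds below may be only part of what the source reports. "The series", "measured", "known", "first", "only" and "open" are said of these compounds alone.

Compound 1, `COc1ccc(-n2c(SC)nnc2-c2cc(OC)c(OC)c(OC)c2)cc1`, in a functional assay on HT-29 cells (Homo sapiens) for inhibition, read by MTT assay, with a stated time of 48 h (a higher number here means a weaker inhibitor, a lower number a stronger inhibitor), reaches only a limit of the assay, > 60000 nM.
Compound 2, `COc1ccc(C(=O)CSc2nnc(-c3cc(OC)c(OC)c(OC)c3)n2-c2ccc(OC)cc2)cc1`, in this assay likewise reaches only a limit, > 60000 nM.
Compound 3, `COc1ccc(-n2c(SCC(=O)c3ccc4ccccc4c3)nnc2-c2cc(OC)c(OC)c(OC)c2)cc1`, in this assay gives 53400 nM.

Compound 1 therefore has no number of its own here, only a limit, and one of the two other values shown is a limit as well. Compound 4, `COc1ccc(-n2c(SCC(=O)C3CC3)nnc2-c2cc(OC)c(OC)c(OC)c2)cc1`, is the compound not yet measured. It differs from compound 1 in one place: cyclopropylcarbonyl in place of hydrogen on a saturated chain carbon bound to a sulfur.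

Going by the values given here, two measured steps touch the same place on the shared core. The step that the two limits leave unreadable from compound 1 to compound 2 cannot be read, since both of its ends are limits. The step of an at least 1.1-fold lower number from compound 1 to compound 3 (0.05 log units; that floor lies within the scatter) is readable only as a floor, and that floor lies within the scatter. The related step of an at least 1.1-fold lower number from compound 2 to compound 3 (0.05 log units; that floor lies within the scatter) likewise shows only a floor within the scatter. Adding a carbonyl-bearing group on the saturated chain carbon bound to a sulfur has so far moved nothing beyond the scatter, and the limit of > 60000 nM in this assay, at which 2 of the 3 values shown sit, shows where most of these values sit. The expected step that the limit leaves unreadable from compound 1 to compound 4 is accordingly no more than the scatter, in no clear direction. Compound 4 is estimated at 70000 nM, within 40000 nM to 150000 nM, and it is expected that the assay may again report only a limit.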

Compound 4, half-maximal inhibitory concentration: > 60000 nM
Compound 4 was reported as a limit; the forecaster's own chance of this, stated with the estimate: 65%; the middle value is on the limit's open side.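

With cyclopropylcarbonyl on the saturated chain carbon bound to a sulfur, a non-aromatic ring joins the aromatic groups that compound 2 and compound 3 carry on the carbonyl, and in this assay the result still sits at the edge of what can be read: the limit of > 60000 nM in this assay, at which 3 of the 4 values shown sit.

Going by these compounds alone, the only step to compound 4 that gives any size is an at least 1.1-fold higher number from compound 3 to compound 4 (0.05 log units; that floor lies within the scatter), so exchanging naphthalen-2-yl for cyclopropyl on the carbonyl carbon shows no change beyond the scatter. The steps from compound 1 and from compound 2 to compound 4 cannot be read, since both ends of each are limits.

From the compounds shown here alone, whether an amine or a carboxylic acid on the saturated chain carbon bound to a sulfur, or a longer chain in that place, would give a value clearly inside the range of this assay remains open. Also open is how much the rest of the shared core matters, since all the compounds shown carry it unchanged and differ only in this one place.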